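A few compounds are considered here, and "the series" means these few. Any claim that something is new, unique, unknown or untested is made for them only; others in the source may bear on it.

Three compounds sharing the core of compound 1 (`CC1(c2ccc(C(=N)N)cc2)NC(=O)N(CC(=O)NC(CC(=O)O)c2cccc3ccccc23)C1=O`) have been measured in a functional assay for inhibition, with Homo sapiens as the target; a higher number here means a weaker inhibitor, a lower number a stronger inhibitor. There compound 1 gives 300 nM, compound 2 (`CC(CC(=O)O)NC(=O)CN1C(=O)NC(C)(c2ccc(C(=N)N)cc2)C1=O`) gives 2000 nM and compound 3 (`C[C@@]1(c2ccc(C(=N)N)cc2)NC(=O)N(CC(=O)N[C@@H](CC(=O)O)c2ccccc2)C1=O`) gives 20 nM. Compound 3 is therefore the strongest inhibitor of the three, with the lowest number on the scale.

Compound 4 (`C[C@]1(c2ccc(C(=N)N)cc2)NC(=O)N(CC(=O)N[C@H](CC(=O)O)c2ccccc2)C1=O`) is related to compound 3 by configuration alone: the two compounds have the same atoms and bonds; at least one stereo element is drawn with a configuration in one of them and without one in the other: 2 of 3 stereo elements differ; a stereocentre at a saturated ring carbon is drawn S in compound 3 and R in compound 4; a stereocentre at a saturated chain carbon is drawn S in compound 3 and R in compound 4. For the measured compounds named here, the one measured step, a 6.7-fold higher number from compound 1 to compound 2 (0.82 log units; beyond the scatter), puts methyl in place of naphthalen-1-yl on a saturated chain carbon. It is modest and concerns the group on such a carbon, not its configuration. Going by the values given here, compounds 1 and 2 are drawn without configuration at their stereocentres, so no measured pair isolates the change now in question, and the expectation is a judgement rather than a read-across.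

Compound 3 holds the lowest value at 20 nM, and both of its stereocentres are inverted in compound 4, so a move to a higher number in this assay is expected, larger than the measured 6.7-fold higher number from compound 1 to compound 2 (0.82 log units; beyond the scatter). The step expected is a 100-fold higher number from compound 3 to compound 4 (2.00 log units; beyond the scatter). For compound 4 the estimated value is 2000 nM, with an expected range from 200 nM to 20000 nM.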

Compound 4, half-maximal inhibitory concentration: 5000 nM
Estimate against measurement, compound 4: 2.5-fold (0.40 log units) below, and the stated range covers the measured number.
By their numbers in this assay, from the lowest: compound 3; then compound 1; then compound 2; then compound 4.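

In this assay, configuration alone, with atoms and bonds unchanged, produces a larger movement than replacing one group with another: the new result is a 250-fold higher number from compound 3 to compound 4 (2.40 log units; beyond the scatter), against the earlier 6.7-fold higher number from compound 1 to compound 2 (0.82 log units; beyond the scatter). The earlier compounds shown here, drawn without configuration at their stereocentres, could not show this, whereas compound 3 at 20 nM and compound 4 at 5000 nM now place the two drawn arrangements far apart. One point qualifies how exactly this pair can be read: the fact that one of compounds 3 and 4 is drawn with a defined configuration and the other without, at the place where they differ.

The saturated ring carbon and the saturated chain carbon are inverted together in this pair, so the compounds shown do not divide the step between the two stereocentres, and a compound with only one of them inverted would be needed to do that. As far as these compounds go, it also remains open whether configuration counts for as much when naphthalen-1-yl stands in place of the phenyl group on the chain carbon, or when an ethyl group stands in place of the methyl group on the ring carbon.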